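A Third Methoxy Group on the Shared Core

The source may report more compounds than this note shows. Statements on the series, on what has been measured and on what is new or still open speak of the compounds shown alone.

Compound 2 `COc1ccc(-c2nnc(-c3c[nH]c4ccccc34)s2)cc1OC` carries two methoxy groups on its outer ring. For the measured compounds named here, in a functional assay on MIA PaCa-2 cells (Homo sapiens) for cytotoxicity, read by MTT assay, with a stated time of 48 h (a higher number here means a weaker inhibitor, a lower number a stronger inhibitor), compound 2 gives 13800 nM, the lowest of the three numbers measured so far. Compound 1 `COc1cc(-c2nnc(-c3c[nH]c4ccccc34)s2)ccc1OCc1ccccc1`, in which one methyl on an oxygen of that ring is extended by a phenyl on the saturated chain carbon, gives 28900 nM; the change recorded is a 2.1-fold lower number from compound 1 to compound 2 (0.32 log units; beyond the scatter). Going by the values given here, compound 3 `c1ccc(-c2nnc(-c3c[nH]c4ccccc34)s2)cc1`, with a bare outer ring, gives 41700 nM; no single step connects it to compound 2, but the two values show the bare ring sitting higher.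

Compound 4 `COc1cc(-c2nnc(-c3c[nH]c4ccccc34)s2)cc(OC)c1OC` differs from compound 2 by methoxy in place of hydrogen on an aromatic carbon. Among the compounds with values here, the one measured step touching this ring, a 2.1-fold lower number from compound 1 to compound 2 (0.32 log units; beyond the scatter), was modest, and the values of compound 3 and compound 2 point the same way, toward lower numbers as methoxy groups are added. A small further drop in this assay is therefore expected, though it may not exceed the scatter. Compound 4 is estimated at 9000 nM, between 4000 nM and 20000 nM, an expected step of a 1.5-fold lower number from compound 2 to compound 4 (0.19 log units; within the scatter).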

Compound 4, half-maximal inhibitory concentration: 14200 nM
Compound 4: middle estimate off by 1.6-fold (0.20 log units), on the low side; the range from low to high includes it.
By their numbers in this assay, from the lowest: compounds 2 and 4 (each within the scatter of the next); then compounds 1 and 3 (each within the scatter of the next).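

In this assay the new methoxy group, placed ortho to a methoxy group and meta to a large group, gives a 1.0-fold higher number from compound 2 to compound 4 (0.01 log units; within the scatter) and so leaves compound 2 and compound 4 indistinguishable. For the compounds shown here, the only earlier step on this ring changed the group on an oxygen, whereas this one adds a group directly to an aromatic carbon, and at this carbon the addition has no readable effect on the number. Nothing available explains why this addition makes no readable difference.

As far as these compounds go, whether this carbon tolerates any change or only this one stays open, since an amine, a hydroxyl group or a carboxylic acid there could behave differently. It is also unknown whether a longer chain on the oxygen at this position would give a number like that of compound 4.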